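Stereocentre inversion in the propylpiperazine analogue

The source may report more compounds than this note shows. Statements on the series, on what has been measured and on what is new or still open speak of the compounds shown alone.

Measured so far in a functional assay on CCRF-CEM cells for antagonist activity at C-X-C chemokine receptor type 4 (Homo sapiens), read by calcium flux, with stated times of 25 min and 90 s; on this read-out lower numbers stand for stronger inhibition and higher numbers for weaker inhibition:
compound 1, `c1ccc2c(c1)CN[C@@H](CN(CC1CCNCC1)[C@H]1CCCc3cccnc31)C2`: 65 nM
compound 2, `c1ccc2c(c1)CN[C@H](CN(CCCN1CCNCC1)[C@H]1CCCc3cccnc31)C2`: 1150 nM

Compound 2 stands with the highest of the two numbers in this assay. Among the measured compounds shown here, the only other value is that of compound 1, and the gap between the two lies beyond the usual scatter. The two compounds differ in both the side chain and the configuration at the ring carbon, so the two differences cannot be separated from these values alone.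

Compound 3, `c1ccc2c(c1)CN[C@@H](CN(CCCN1CCNCC1)[C@H]1CCCc3cccnc31)C2`, is not yet measured. Relative to compound 2 the change is: the two compounds have the same atoms and bonds and differ only in configuration as drawn: 1 of 2 stereo elements differ; a stereocentre at a saturated ring carbon is drawn S in compound 2 and R in compound 3. For the measured compounds named here, the configuration of compound 3 at that centre matches the one drawn for compound 1.

Going by the values given here, no directly comparable step within the measured pair is available. Since compound 1, carrying the same configuration, gives 65 nM, the expectation is that inversion moves compound 3 toward a lower number, and the step from compound 2 to compound 3 is estimated at a 7.7-fold lower number from compound 2 to compound 3 (0.88 log units; beyond the scatter). Compound 3 is expected to give about 150 nM in this assay, in the range 45 nM to 600 nM.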

Compound 3, half-maximal inhibitory concentration: 17 nM
Estimate against measurement, compound 3: 8.8-fold (0.95 log units) above, outside the stated range (below it).
By their numbers in this assay, from the lowest: compound 3; then compound 1; then compound 2.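

In this assay the stereocentre at the saturated ring carbon carries a large effect, a 68-fold lower number from compound 2 to compound 3 (1.83 log units; beyond the scatter), with the form drawn R on the low side. This separates the two differences left entangled in the earlier pair, and the step can be assigned to configuration alone: the fact that compounds 2 and 3 differ only in the configuration as drawn. With the configuration held at R, 2-(piperazin-1-yl)ethyl in place of piperidin-4-yl on a saturated chain carbon bound to an amine nitrogen gives a modest but real change, a 3.8-fold lower number from compound 1 to compound 3 (0.58 log units; beyond the scatter), a smaller step than the one from inversion.

The compounds shown leave open whether inversion at this centre carries the same weight with the piperidin-4-yl side chain, and what inversion of the second stereocentre, drawn alike in all three compounds, would do. Also open, as far as these compounds go, is how a longer chain ending in a primary amine, in place of the 2-(piperazin-1-yl)ethyl group, would read in this assay with the R configuration kept.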